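The source may report more compounds than this note shows. Statements on the series, on what has been measured and on what is new or still open speak of the compounds shown alone.

Compound 1 `Cc1cc(-c2cnc(NCc3c(F)ccc4c3CCO4)c3cn[nH]c(=O)c23)n(C)n1` gives 24 mL.min-1.g-1 in an ADME assay on microsomes from liver (Homo sapiens) for metabolic stability, read by LC-MS, using NADPH, with stated times of 5 min and 30 min, tested at 1 uM; on this read-out lower numbers stand for slow clearance and higher numbers for fast clearance.
Compound 2 `O=C1CCCN1c1cnc(NCc2c(F)ccc3c2CCO3)n2cnnc12` gives < 3 mL.min-1.g-1 in this assay, and this is a limit of the assay rather than a measured number.

Going by the values given here, of the two compounds measured so far, compound 1 is the one with a number that the assay could resolve, while compound 2 sits at the limit of < 3 mL.min-1.g-1 in this assay, at which 1 of the 2 values shown sits, so its true clearance is known only to be somewhere under that bound. Among the compounds with values here, no pair of measured compounds differs in a single place, so no measured step is available to lean on.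

Compound 3 `COCCC(=O)Nc1cnc(NCc2c(F)ccc3c2CCO3)n2cnnc12` has not yet been measured. It differs from compound 2 in one place: ((2-methoxyethyl)carbonyl)amino in place of 2-oxopyrrolidin-1-yl on an aromatic carbon. The five-membered non-aromatic ring of the 2-oxopyrrolidin-1-yl group gives way to an open chain with one hydrogen-bond donor and two acceptors.

Since compound 2 already rests at the limit, the step is expected to run upward rather than down, and to stay close to the usual scatter: the estimated step is an at least 1.6-fold higher number from compound 2 to compound 3 (0.22 log units; that floor lies within the scatter). Compound 3 is therefore expected to give about 5 mL.min-1.g-1 in this assay, with a plausible range from 3 mL.min-1.g-1 to 15 mL.min-1.g-1, and a real chance that it too is reported only as a limit.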

Compound 3, intrinsic clearance in microsomes: < 3 mL.min-1.g-1
Compound 3: only a limit was reported; the forecaster's own chance of this, stated with the estimate: 35%; middle value at least 1.6-fold (0.22 log units) away from the limit.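

Compound 2 and compound 3 both rest at a limit of the assay, so no step from one to the other can be read in this assay: the limit of < 3 mL.min-1.g-1 in this assay, at which 2 of the 3 values shown sit.

From the compounds shown here alone, the true clearance of each of these two compounds stays open, and with it whether 2-oxopyrrolidin-1-yl and ((2-methoxyethyl)carbonyl)amino differ at all on this read-out.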